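The source may hold more compounds than are shown below. What is called first, only, known or untested is meant among the compounds shown, and "the series" means these compounds.

Compound 3 `c1ccc2c(c1)CN[C@@H](CN(CCN1CCNCC1)[C@H]1CCCc3cccnc31)C2` stands highest of the three compounds measured in an ADME assay on microsomes from liver (Mus musculus) for metabolic stability, read by LC-MS, with a stated time of 10 min, tested at 0.5 uM (a higher number here means that more of the compound is left, a lower number that less of the compound is left), where compound 3 gives 79%. Compound 1 `c1ccc2c(c1)CN[C@@H](CN(CC[C@@H]1CCCNC1)[C@H]1CCCc3cccnc31)C2` gives 23%, and compound 2 `c1ccc2c(c1)CN[C@@H](CN(CCC1CCNCC1)[C@H]1CCCc3cccnc31)C2` gives 32%. The step of a number 9 percentage points higher from compound 1 to compound 2 (within the scatter) lies within the scatter, whereas a number 56 percentage points higher from compound 1 to compound 3 (beyond the scatter) and a number 47 percentage points higher from compound 2 to compound 3 (beyond the scatter) are both large. Compound 4 `c1ccc2c(c1)CN[C@@H](CN(CC[C@H]1CCCNC1)[C@H]1CCCc3cccnc31)C2` differs from compound 3 by piperidin-3-yl in place of piperazin-1-yl on a saturated chain carbon, two bonds along the chain from an amine nitrogen. Both large steps bear directly on this change, as each followed the entry of the group that now leaves. Since that group's entry brought a number 47 percentage points higher from compound 2 to compound 3 (beyond the scatter) and compound 4 takes it away again, a fall of like size is expected, a number 54 percentage points lower from compound 3 to compound 4 (beyond the scatter). Compound 4 is therefore estimated at 25%, with a range from 10% to 45%.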

Compound 4, percent of the compound remaining: 56%
The estimate for compound 4 lay 31 percentage points below the measured number, outside the stated range (above it).
By their numbers in this assay, from the lowest: compounds 1 and 2 (each within the scatter of the next); then compound 4; then compound 3.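

In this assay, piperidin-3-yl at this position has no single outcome, since its two drawn forms give a step of a number 33 percentage points higher from compound 1 to compound 4 (beyond the scatter), and only stereochemistry separates them: the fact that compounds 1 and 4 differ only in the configuration as drawn

In this configuration, the exchange for piperazin-1-yl gives a number 23 percentage points lower from compound 3 to compound 4 (beyond the scatter), while the exchange for piperidin-4-yl gives a number 24 percentage points higher from compound 2 to compound 4 (beyond the scatter). The ring type alone therefore does not fix the percentage remaining.

The compounds shown leave open how 4-methylpiperazin-1-yl or morpholin-4-yl would fare in the same place. They also leave open whether the gap between the two configurations would persist on a longer chain.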